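The source may report more compounds than this note shows. Statements on the series, on what has been measured and on what is new or still open speak of the compounds shown alone.

The measured compounds in an assay on isolated protein for inhibition of cathepsin S (Homo sapiens); a lower number here means a stronger inhibitor, a higher number a weaker inhibitor:

Compound 1, `N#C[C@@]1(NC(=O)[C@@H](CC(=O)N2CCOCC2)CC2CCCCC2)CCNC1`: 141 nM
Compound 2, `N#C[C@@]1(NC(=O)[C@@H](CC(=O)N2CCOCC2)CC2CCCCC2)CCN(C2CCCCC2)C1`: 23 nM
Compound 3, `N#C[C@@]1(NC(=O)[C@@H](CC(=O)N2CCOCC2)CC2CCCCC2)CCN(C2CCCCCC2)C1`: 23 nM

In this assay compound 3 stands level with compound 2, and together they hold the lowest of the three numbers; compound 1, which carries hydrogen on the ring amine nitrogen, gives 141 nM. Compound 4, `CN1CC[C@@](C#N)(NC(=O)[C@@H](CC(=O)N2CCOCC2)CC2CCCCC2)C1`, differs from compound 3 by methyl in place of cycloheptyl on an amine nitrogen in a ring. Among the compounds with values here, the steps that bear on this are a 6.1-fold lower number from compound 1 to compound 2 (0.79 log units; beyond the scatter) and a 6.1-fold lower number from compound 1 to compound 3 (0.79 log units; beyond the scatter), while no change at the digits printed from compound 2 to compound 3 (within the scatter). A methyl group counts fewer heavy atoms than either ring group yet more than hydrogen, so compound 4 is expected to land between compound 1 and compound 3. The expected step is a 2.6-fold higher number from compound 3 to compound 4 (0.42 log units; beyond the scatter). Compound 4 is estimated at 60 nM, with a range from 25 nM to 150 nM.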

Compound 4, half-maximal inhibitory concentration: 155 nM
For compound 4 the middle estimate is 2.6-fold (0.41 log units) below the measured one; measured number outside the range, above it.
By their numbers in this assay, from the lowest: compounds 2 and 3 (each within the scatter of the next); then compounds 1 and 4 (each within the scatter of the next).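

In this assay, within the data shown here, methyl on the ring amine nitrogen proves no halfway step: the change gives a 1.1-fold higher number from compound 1 to compound 4 (0.04 log units; within the scatter), while the ring groups stand clearly apart, with a 6.7-fold higher number from compound 3 to compound 4 (0.83 log units; beyond the scatter) and a 6.7-fold higher number from compound 2 to compound 4 (0.83 log units; beyond the scatter). Among these compounds, then, a single carbon on this nitrogen matches hydrogen, and the gain appears only with cyclohexyl or cycloheptyl. No measurement shown offers an explanation for this. Still open, as far as these compounds go, is whether the gain builds gradually or requires a ring; ethyl, isopropyl and cyclopentyl on this nitrogen would help to settle that.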